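From nitro to fluoro on the phenylpiperazine ring

The source may report more compounds than this note shows. Statements on the series, on what has been measured and on what is new or still open speak of the compounds shown alone.

Of the compounds shown here, three sharing one core have been measured in an assay on HEK293 cells with D(4) dopamine receptor (Homo sapiens) as the target, read by FLIPR; on this read-out lower numbers stand for an effect already at smaller amounts and higher numbers for an effect only at larger amounts of compound. Compound 1 `N#Cc1ccccc1N1CCN(Cc2nc3ccccc3[nH]2)CC1` gives 14.6 nM. Compound 2 `Fc1cccnc1N1CCN(Cc2nc3ccccc3[nH]2)CC1` gives 24 nM, and the step of a 1.6-fold higher number from compound 1 to compound 2 (0.22 log units; within the scatter) lies within the scatter of the assay. Compound 3 `O=[N+]([O-])c1ccccc1N1CCN(Cc2nc3ccccc3[nH]2)CC1` gives 3.9 nM, the lowest of the three numbers; the step of a 3.7-fold lower number from compound 1 to compound 3 (0.57 log units; beyond the scatter) sets it apart from compound 1 and it lies further still from compound 2.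

Compound 4 `Fc1ccccc1N1CCN(Cc2nc3ccccc3[nH]2)CC1` has not been measured. It differs from compound 3 by fluoro in place of nitro on an aromatic carbon, that is, on an aromatic carbon of a six-membered aromatic ring of carbon only, ortho to a large group. Among the measured compounds shown here, only one measured step touches this position, the exchange of cyano for nitro from compound 1 to compound 3, which gave a modest change, and it suggests that the group at this position matters. Fluoro is a smaller group than either cyano or nitro, so the step in this assay is expected to run back toward higher numbers, about the size of a 7.7-fold higher number from compound 3 to compound 4 (0.89 log units; beyond the scatter) and beyond the scatter. For compound 4 the estimate in this assay is 30 nM, within a range from 8 nM to 110 nM.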

Compound 4, half-maximal effective concentration: 14.7 nM
Compound 4: the middle estimate sits 2.0-fold (0.31 log units) above what was measured; the measured number falls inside the stated range.
By their numbers in this assay, from the lowest: compound 3; then compounds 1, 4 and 2 (each within the scatter of the next).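

In this assay, among the compounds shown here, nitro is the one group at this aromatic carbon that stands apart so far: exchanging it for fluoro gives a modest step (a 3.8-fold higher number from compound 3 to compound 4 (0.58 log units; beyond the scatter)), so two different groups have now been compared with nitro and both part from it beyond the scatter. Fluoro and cyano, by contrast, cannot be told apart here (a 1.0-fold higher number from compound 1 to compound 4 (0.00 log units; within the scatter)), so this position does not respond to every exchange of group, and the single heavy atom of fluoro does as well as the nitrile. Keeping the fluoro and exchanging the whole aromatic ring also stays within the scatter (a 1.6-fold lower number from compound 2 to compound 4 (0.21 log units; within the scatter)), so 2-fluorophenyl and 3-fluoropyridin-2-yl cannot be separated in this pair.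

Nothing available here speaks to what lies behind the separate place of nitro. From the compounds shown here alone, it remains open whether an amine, a methoxy group or a carboxylic acid on this same aromatic carbon would fall in with nitro or with fluoro and cyano, and so whether nitro is a lone case or one of a wider set.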